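From compound 2 to compound 3: adding a nitro group

This account rests on a few compounds, and the source may have more. Where it says the series, first, only, none or still open, it means among the compounds named here.

Compound 1 `O=C(N/N=C/c1ccccc1)c1ccc([N+](=O)[O-])o1`: "not determined" (no result reported)
Compound 2 `C/C(=N\NC(=O)c1ccc([N+](=O)[O-])o1)c1ccccc1`: > 228000 nM

In an ADME assay on Vero cells (Chlorocebus sabaeus) for cytotoxicity, read by MTT assay, with a stated time of 72 h (on this read-out lower numbers stand for higher toxicity in this test and higher numbers for lower toxicity in this test), compound 2 gives > 228000 nM, which is a limit of the assay and not a number. Compound 3 `C/C(=N\NC(=O)c1ccc([N+](=O)[O-])o1)c1ccc([N+](=O)[O-])cc1` differs from compound 2 in one place: nitro in place of hydrogen on an aromatic carbon, with nitro in place of hydrogen on an aromatic carbon, para to a large group. Among the measured compounds shown here, no measured step between compounds shows how large such a change may be in this assay, so only a modest fall in the read-out is expected, and another limit would be no surprise. The expected change is an at least 1.9-fold lower number from compound 2 to compound 3 (0.27 log units; that floor lies within the scatter). The estimate for compound 3 is 120000 nM, within an expected range of 30000 nM to 300000 nM.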

Compound 3, half-maximal cytotoxic concentration: > 196000 nM
Compound 3: no number, only a limit; the forecaster's own chance of this, stated with the estimate: 50%; middle value at least 1.6-fold (0.21 log units) away from the limit.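

Compound 2 and compound 3 each give only a limit in this assay, and the step between them cannot be read. The compounds shown leave open whether nitro in place of hydrogen on an aromatic carbon changes the read-out at all.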